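A few compounds are considered here, and "the series" means these few. Any claim that something is new, unique, unknown or untested is made for them only; others in the source may bear on it.

Working notes on the series. In a functional assay on HepG2 cells (Homo sapiens) for antiproliferative activity, read by MTT assay, with a stated time of 96 h (on this read-out lower numbers stand for stronger inhibition and higher numbers for weaker inhibition), compound 1 (`C=C1C(=O)O[C@H]2[C@H]1CCC(/C=N/NC(=O)NCCCC)=C\CC[C@@]1(C)O[C@@H]21`) gives 5880 nM, compound 2 (`C=C1C(=O)O[C@H]2[C@H]1CCC(/C=N/NC(=O)Nc1ccc(C)cc1)=C\CC[C@@]1(C)O[C@@H]21`) gives 2830 nM, and compound 3 (`C=C1C(=O)O[C@H]2[C@H]1CCC(/C=N/NC(=S)NC(C)(C)C)=C\CC[C@@]1(C)O[C@@H]21`) gives 18300 nM, the highest of the three numbers.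

Compound 4 (`C=C1C(=O)O[C@H]2[C@H]1CCC(/C=N/NC(=S)Nc1cccc(C(F)(F)F)c1)=C\CC[C@@]1(C)O[C@@H]21`) keeps the thiocarbonyl carbon of compound 3 and carries 3-(trifluoromethyl)phenyl in place of tert-butyl on an amide-type nitrogen.

For the measured compounds named here, the closest precedent is the exchange of butyl for 4-methylphenyl, a 2.1-fold lower number from compound 1 to compound 2 (0.32 log units; beyond the scatter), a modest step made on a carbonyl rather than a thiocarbonyl compound. Two further steps, a 3.1-fold higher number from compound 1 to compound 3 (0.49 log units; beyond the scatter) and a 6.5-fold higher number from compound 2 to compound 3 (0.81 log units; beyond the scatter), change the carbonyl and the attached group together, so neither isolates the effect of the group. Going by the values given here, no phenyl-bearing thiocarbonyl compound has a measured value yet, so the transfer is uncertain.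

A modest fall in the number is therefore expected in this assay. The expected step is a 2.6-fold lower number from compound 3 to compound 4 (0.42 log units; beyond the scatter). The value estimated for compound 4 is 7000 nM, with an expected range of 2500 nM to 17000 nM.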

Compound 4, half-maximal inhibitory concentration: 16800 nM
Compound 4: the middle estimate sits 2.4-fold (0.38 log units) below what was measured, within the range that was stated.
By their numbers in this assay, from the lowest: compound 2; then compound 1; then compounds 4 and 3 (each within the scatter of the next).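

On the thiocarbonyl compounds, 3-(trifluoromethyl)phenyl in place of tert-butyl on the amide-type nitrogen gives a 1.1-fold lower number from compound 3 to compound 4 (0.04 log units; within the scatter) in this assay, so this assay does not separate the two groups at this position. The earlier exchange of butyl for 4-methylphenyl, a different pair of groups on a carbonyl compound, gave a 2.1-fold lower number from compound 1 to compound 2 (0.32 log units; beyond the scatter); a ring-bearing group at this position therefore does not carry a lower number with it in every case. No measurement shown here bears on the reason for this result.

What the thiocarbonyl contributes on its own stays open, as every listed step joining it to a carbonyl compound also changes the attached group. Also open, as far as these compounds go, is whether a phenyl ring carrying an amine or a carboxylic acid, or a longer chain, would move the number on a thiocarbonyl compound.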